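Cytotoxicity of Three Aryl-Substituted Analogues in Macrophage Cells

The compounds below may be only part of what the source reports. "The series", "measured", "known", "first", "only" and "open" are said of these compounds alone.

Measured compounds:
compound 1 `N=C1S/C(=C\c2ccc(OCc3ccccc3)cc2)C(=O)N1c1ccc(F)cc1` — 10.5%
compound 2 `N=C1S/C(=C\c2ccc(OCc3ccccc3)cc2)C(=O)N1c1cccc([N+](=O)[O-])c1` — 52.9%

In an ADME assay on RAW264.7 cells (Mus musculus) for cytotoxicity, read by MTT assay, with a stated time of 48 h, tested at 50 uM (a higher number here means more inhibition at the concentration tested (going by the name of the read-out), a lower number less inhibition), compound 1 gives 10.5%. Among the measured compounds shown here, compound 2 gives 52.9% in this assay, and with that it stands at the top of the two numbers known so far; the step of a number 42.4 percentage points higher from compound 1 to compound 2 (beyond the scatter) is the only step measured. Compound 3 `Cc1c(Cl)cccc1N1C(=N)S/C(=C\c2ccc(OCc3ccccc3)cc2)C1=O` has not been measured. Relative to compound 2 it differs in one place: 3-chloro-2-methylphenyl in place of 3-nitrophenyl on an amide-type nitrogen in a ring.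

For the measured compounds named here, the one step that bears on this change is the step from compound 1 to compound 2, in which a 4-fluorophenyl gave way to a 3-nitrophenyl on the same nitrogen and the reading rose by a large amount. Compound 3 moves away from the nitrophenyl again toward a halogen-bearing phenyl, so a drop back toward the level of compound 1 is expected, though the methyl and chlorine together are new and the size of the drop is uncertain. Compound 3 is therefore estimated at 22% in this assay, within 5% to 45%, which means an expected step of a number 30.9 percentage points lower from compound 2 to compound 3 (beyond the scatter).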

Compound 3, a percentage reported as inhibition, at one concentration (the size of the read-out at that concentration, not a potency): 59.7%
Compound 3: the middle estimate sits 37.7 percentage points below what was measured; the whole stated range lies below it.
By their numbers in this assay, from the lowest: compound 1; then compounds 2 and 3 (each within the scatter of the next).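

In this assay the 3-chloro-2-methylphenyl on the amide-type nitrogen in a ring reads level with the 3-nitrophenyl, with a number 6.8 percentage points higher from compound 2 to compound 3 (within the scatter), so among these compounds a high reading at this position is not confined to the compound with the nitro group. Against the 4-fluorophenyl the same group gives a number 49.2 percentage points higher from compound 1 to compound 3 (beyond the scatter), which leaves compound 1 as the only low reading of the three and shows that a halogen on this phenyl does not by itself go with a low reading, since compound 3 carries chlorine. Nothing at hand explains why these aryl groups separate as they do.

As far as these compounds go, the chlorine and the methyl enter together in compound 3, so the share of each in the reading stays unknown, as does the reading of a phenyl carrying only one of them. The compounds also leave open how the reading would respond to a phenyl carrying an amine or a carboxylic acid at this position, or to a longer alkyl chain on this nitrogen in place of the aryl ring.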